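This account rests on a few compounds, and the source may have more. Where it says the series, first, only, none or still open, it means among the compounds named here.

Compound 1 `Cc1ccccc1-n1nc(C)c2c1NC(=O)[C@H](C)S[C@@H]2c1ccc(Oc2ccccc2C(=O)O)cc1` carries a 2-carboxyphenoxy group on its outer aromatic ring. In an assay on isolated protein for agonist activity at Bile acid receptor (Homo sapiens), read by AlphaScreen, with a stated time of 30 min (on this read-out higher numbers stand for an effect only at larger amounts of compound and lower numbers for an effect already at smaller amounts), compound 1 is reported as "not active" (no number reported), so no number stands for it and its place among the measured compounds cannot be fixed. Among the compounds with values here, two relatives of the same core were measured: compound 2 `Cc1nn(-c2ccccc2C(C)C)c2c1[C@@H](c1ccc(Oc3ccccc3)cc1)S[C@@H](C)C(=O)N2` gives 1900 nM in this assay, and compound 3 `CCCc1ccccc1-n1nc(C)c2c1NC(=O)[C@H](C)S[C@@H]2c1ccc(Oc2ccccc2)cc1` gives 1100 nM; the one step between them, a 1.7-fold lower number from compound 2 to compound 3 (0.24 log units; within the scatter), concerns the group on the other aromatic ring and says nothing about the change at hand.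

Compound 4 `Cc1ccccc1-n1nc(C)c2c1NC(=O)[C@H](C)S[C@@H]2c1ccc(-c2ccco2)cc1` differs from compound 1 by furan-2-yl in place of 2-carboxyphenoxy on an aromatic carbon. Within the data shown here, no measured step touches this exchange, so nothing in the data sets its size or direction; the only hint is that compound 2 and compound 3, which also lack the 2-carboxyphenoxy group, are active in this assay while compound 1 is not. Compound 4 is therefore expected to show activity in the range of those two, and its half-maximal effective concentration in this assay is estimated at 2000 nM, with a likely range from 500 nM to 8000 nM.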

Compound 4, half-maximal effective concentration: 3600 nM
Compound 4: middle estimate off by 1.8-fold (0.26 log units), on the low side; the range from low to high includes it.
By their numbers in this assay, from the lowest: compounds 3, 2 and 4 (each within the scatter of the next, the first and the last beyond it).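

No step can be read from compound 1 to compound 4: compound 1 stands without a number, and compound 2 and compound 3 differ from compound 4 in more than one place. Going by these compounds, what the exchange of 2-carboxyphenoxy for furan-2-yl does alone stays open, and no evidence here bears on the result.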